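Acetyl in Place of Methyl on a Urea

The source may report more compounds than this note shows. Statements on the series, on what has been measured and on what is new or still open speak of the compounds shown alone.

Three compounds have so far been measured in an ADME assay on the whole organism with Oryza sativa as the target, tested at 0.1 uM; on this read-out higher numbers stand for a weaker effect at the one concentration tested and lower numbers for a stronger effect:

compound 1, `Cc1cccc(NC(=O)N[C@H](C)c2ccccc2)c1`, gives 100%
compound 2, `Cc1cccc(NC(=O)N[C@@H](C)c2ccccc2)c1`, gives 99%
compound 3, `CCCCCCc1ccc(NC(=O)N[C@@H](C)c2ccccc2)cc1`, gives 99%

All three numbers sit at the top of the scale, so at the single concentration tested none of them shows more than a trace of an effect. Compound 2 stands level with compound 3 at the digits given, and these two are together the lowest of the three numbers; compound 1 lies only a little higher, still within the scatter. Among the compounds with values here, the one step between compounds that differ in a single place is a number 1 percentage points lower from compound 1 to compound 2 (within the scatter), and it rests on (the fact that compounds 1 and 2 differ only in the configuration as drawn); it does not reach beyond the scatter.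

Compound 4, `CC(=O)c1cccc(NC(=O)N[C@@H](C)c2ccccc2)c1`, has not yet been measured. Compared with compound 2 the change is acetyl in place of methyl on an aromatic carbon. Within the data shown here, no measured step involves an acetyl group, so nothing among the measured compounds tells how this change acts here; compound 3 differs from compound 2 in more than one place, and its value only shows the same near-absence of effect. Among the measured compounds shown here, with every measured number at the top of the scale and the only measured step within the scatter, the expected step is a number 1 percentage points lower from compound 2 to compound 4 (within the scatter), that is, no change beyond the scatter. Compound 4 is therefore estimated at 98%, in a range from 85% to 100%.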

Compound 4, a percentage reported as activity, at one concentration (the size of the read-out at that concentration, not a potency): 96%
The estimate for compound 4 lay 2 percentage points above the measured number; the range from low to high includes it.
By their numbers in this assay, from the lowest: compounds 4, 2, 3 and 1 (each within the scatter of the next).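

The step of a number 3 percentage points lower from compound 2 to compound 4 (within the scatter) in this assay comes from acetyl in place of methyl on an aromatic carbon, meta to a large group. Within the data shown here, it shows that this place on the ring can carry a larger group, with a carbonyl that adds a hydrogen-bond acceptor, without any change beyond the scatter, so the number for compound 4 remains near the top of the scale, as for the earlier compounds. No available fact about these compounds bears on this step.

Acetyl is the only replacement for methyl at this place, so it remains open whether an amine, a carboxylic acid or a longer chain there would shift the number beyond the scatter. Also open, going by these compounds, are whether acetyl would behave the same way on another ring carbon or with the configuration drawn in compound 1, and whether this unchanged read-out would hold at any concentration other than the one tested.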